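A few compounds are considered here, and "the series" means these few. Any claim that something is new, unique, unknown or untested is made for them only; others in the source may bear on it.

Measured in a functional assay on MCF7 cells (Homo sapiens) for inhibition, read by sulforhodamine B assay, with a stated time of 48 h; on this read-out higher numbers stand for weaker inhibition of growth and lower numbers for stronger inhibition of growth:
Compound 1 `CC1(/C=C/c2ccc(C(F)(F)F)cc2)C=CC(=O)O1`: 20400 nM
Compound 2 `COc1c(O)ccc(/C=C/C2(C)C=CC(=O)O2)c1OC`: 45300 nM

Of these two, compound 1 has the lower number, 20400 nM, and so the stronger inhibition of growth; the gap to compound 2 lies beyond the usual scatter. Compound 3 `COc1ccc(/C=C/C2(C)C=CC(=O)O2)cc1` keeps the core of compound 1 but carries methoxy in place of trifluoromethyl on an aromatic carbon. Compound 2, which also carries methoxy but differs elsewhere too, gives 45300 nM, so a modest rise in this assay is expected, perhaps no larger than the scatter. The expected change is a 1.5-fold higher number from compound 1 to compound 3 (0.17 log units; within the scatter). For compound 3 the estimated value is 30000 nM, with an expected range of 14000 nM to 60000 nM.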

Compound 3, concentration for total growth inhibition: 183000 nM
Compound 3: middle estimate off by 6.1-fold (0.79 log units), on the low side, and the stated range ends below it.
By their numbers in this assay, from the lowest: compound 1; then compound 2; then compound 3.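

Within this assay, putting methoxy in place of trifluoromethyl on the aromatic ring gives a 9.0-fold higher number from compound 1 to compound 3 (0.95 log units; beyond the scatter) with the rest of the molecule unchanged. This is the first pair shown that differs in one place only, and it shows that growth inhibition is sensitive to the group at this position. Nothing available here explains why this change weakens inhibition.

Going by these compounds alone, with only two groups compared at this position, it remains open how a nitrile, an amine or a single chlorine atom would behave there.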